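The compounds below may be only part of what the source reports. "The series", "measured", "known", "first", "only" and "open" are said of these compounds alone.

Compound 1 `O[C@@H]1[C@@H](O)[C@H](Oc2cccc3cccc(S)c23)OC[C@H]1O` gives 45 uM; compound 2 `Oc1ccc(S[C@@H]2OC[C@@H](O)[C@H](O)[C@H]2O)c2ccccc12` gives 160 uM.

Measured in a functional assay on T-24 cells (Homo sapiens) for antiproliferative activity, read by crystal violet staining, with a stated time of 96 h (a lower number here means that less compound is needed, a higher number that more compound is needed for the effect), compound 1 holds the lower of the two numbers, and compound 2 sits beyond the usual scatter above it. Compound 3 `CCCSc1cccc2cccc(O[C@@H]3OC[C@@H](O)[C@H](O)[C@H]3O)c12` differs from compound 1 by a single change: propyl in place of hydrogen on a sulfur. Within the data shown here, no measured pair shows this change, so its effect cannot be read from data. A step of a 1.5-fold lower number from compound 1 to compound 3 (0.18 log units; within the scatter) from compound 1 to compound 3 is expected, small and toward a lower number, though not clearly beyond the scatter. Compound 3 is estimated at 30 uM, between 8 uM and 120 uM.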

Compound 3, concentration for half-maximal effect: 155 uM
The estimate for compound 3 lay 5.2-fold (0.71 log units) below the measured number; measured number above the stated range.
By their numbers in this assay, from the lowest: compound 1; then compounds 3 and 2 (each within the scatter of the next).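

Compound 1 carries a hydrogen on the sulfur, and putting propyl there gives a 3.4-fold higher number from compound 1 to compound 3 (0.54 log units; beyond the scatter) in this assay. Among these compounds, this is the first measured change at this position, and it shows that the position is sensitive: going from sulfanyl to propylsulfanyl means that more compound is needed for the effect. Nothing in the data shown bears on why this happens. As far as these compounds go, whether a smaller methyl on the sulfur would give a number closer to that of compound 1 remains open. So does the effect of a longer chain or of a chain ending in an amine.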